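From an amine chain to a butyl carbonate

A few compounds are considered here, and "the series" means these few. Any claim that something is new, unique, unknown or untested is made for them only; others in the source may bear on it.

Compound 3, `Cc1cn(C2CC(N=[N+]=[N-])C(COC(=O)CCCN)O2)c(=O)[nH]c1=O`, carries a 3-aminopropyl chain on a carbonyl carbon of the shared core. Within the data shown here, in a physicochemical assay for lipophilicity (a lower number here means a more polar compound, a higher number a more lipophilic compound), compound 3 gives -0.9, the lowest of the three numbers measured so far. Compound 2, `Cc1cn(C2CC(N=[N+]=[N-])C(COC(=O)NCCCC(=O)O)O2)c(=O)[nH]c1=O`, gives -0.81, and the step of a number 0.09 log units lower from compound 2 to compound 3 (within the scatter) is too small to tell the two apart. Compound 1, `Cc1cn(C2CC(N=[N+]=[N-])C(COC(=O)CCCC(=O)OC(C)(C)C)O2)c(=O)[nH]c1=O`, gives 1.17, and the steps of a number 1.98 log units lower from compound 1 to compound 2 (beyond the scatter) and a number 2.07 log units lower from compound 1 to compound 3 (beyond the scatter) are both large.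

Compound 4, `CCCCOC(=O)OCC1OC(n2cc(C)c(=O)[nH]c2=O)CC1N=[N+]=[N-]`, differs from compound 3 by butoxy in place of 3-aminopropyl on a carbonyl carbon. The group that leaves brings one hydrogen-bond donor; the group that enters brings none. The measured steps that bear on this change are the two large drops from compound 1: replacing a tert-butoxycarbonyl with an amino group, or a 3-(tert-butoxycarbonyl)propyl with a (3-carboxypropyl)amino group, lowered the number well beyond the scatter. Moving in the opposite direction here, from an amine-bearing chain to a butoxy group, an upward step of similar size is expected, a number 2.30 log units higher from compound 3 to compound 4 (beyond the scatter). Compound 4 is therefore estimated to give about 1.4, with a likely range from 0.9 to 1.9, landing near compound 1.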

Compound 4, partition coefficient: 1.02
Compound 4: the middle estimate sits 0.38 log units above what was measured, and the stated range covers the measured number.
By their numbers in this assay, from the lowest: compounds 3 and 2 (each within the scatter of the next); then compounds 4 and 1 (each within the scatter of the next).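

In this assay, butoxy on this carbonyl carbon stands well apart from both polar-ended chains: putting it in place of 3-aminopropyl gives a number 1.92 log units higher from compound 3 to compound 4 (beyond the scatter), and putting it in place of (3-carboxypropyl)amino gives a number 1.83 log units higher from compound 2 to compound 4 (beyond the scatter). Among these compounds, the new comparison with the only other high compound gives a number 0.15 log units lower from compound 1 to compound 4 (within the scatter), so butoxy and 3-(tert-butoxycarbonyl)propyl cannot be told apart here, and a high number at this position does not depend on having the tert-butoxycarbonyl group. Nothing measured here explains why these steps have the sizes they do.

The compounds shown leave open how much of the large rise from compound 3 goes with losing the amino end of the chain and how much goes with the oxygen that joins butoxy to the carbonyl carbon, a question that a plain pentyl chain on the same carbon would help to separate. They also leave open how the number follows the length of the chain, for instance with ethoxy or octyloxy in place of butoxy.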